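The source may hold more compounds than are shown below. What is called first, only, known or untested is meant among the compounds shown, and "the series" means these compounds.

Measured in a functional assay on A549 cells (Homo sapiens) for inhibition, read by MTT assay, with a stated time of 48 h; a lower number here means a stronger inhibitor, a higher number a weaker inhibitor:
- compound 1 `Cn1c(/C=C2\SC(=O)N(CC(=O)Nc3cc(C(C)(C)C)on3)C2=O)nc2ccccc21`: 15300 nM
- compound 2 `Cn1c(/C=C2\SC(=O)N(CC(=O)N3CCOCC3)C2=O)nc2ccccc21`: 38500 nM
- compound 3 `Cn1c(/C=C2\SC(=O)N(CC(=O)N3CCCCC3)C2=O)nc2ccccc21`: > 50000 nM (a limit of the assay)

Of the two values that are true numbers, compound 2 has the higher, at 38500 nM, and compound 1 gives 15300 nM. Compound 3 gives only a limit.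

Compound 4 `CC(C)n1c(/C=C2\SC(=O)N(CC(=O)N3CCOCC3)C2=O)nc2ccccc21` differs from compound 2 in one place: isopropyl in place of methyl on an aromatic nitrogen. Among the measured compounds shown here, no measured step touches that nitrogen. All three measured steps change the group on the carbonyl carbon: a 2.5-fold higher number from compound 1 to compound 2 (0.40 log units; beyond the scatter), an at least 3.2-fold higher number from compound 1 to compound 3 (0.51 log units; beyond the scatter) and an at least 1.2-fold higher number from compound 2 to compound 3 (0.11 log units; that floor lies within the scatter). For the measured compounds named here, they therefore give only a rough scale, and the change at the nitrogen has no direct precedent here. With the modest 2.5-fold higher number from compound 1 to compound 2 (0.40 log units; beyond the scatter) as the nearest guide to size, no shift beyond the scatter is expected in this assay, and no direction is favoured. The expected change is a 1.2-fold lower number from compound 2 to compound 4 (0.08 log units; within the scatter). Compound 4 is estimated at 32000 nM, with an expected range from 14000 nM to 50000 nM.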

Compound 4, half-maximal inhibitory concentration: > 50000 nM
Compound 4 was reported as a limit; the forecaster's own chance of this, stated with the estimate: 25%; at least 1.5-fold (0.19 log units) between middle value and limit.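

In this assay compound 4 gives > 50000 nM, which is a limit of the assay and not a number. Among the compounds shown here, this is the first change on the aromatic nitrogen, where the earlier compounds all carry methyl, and it reads as an at least 1.2-fold higher number from compound 2 to compound 4 (0.11 log units; that floor lies within the scatter), so isopropyl gives no lower number here, while the true size of the step stays hidden. Compound 4 thus sits at the same limit as compound 3, and this ceiling constrains what the series can show: the limit of > 50000 nM in this assay, at which 2 of the 4 values shown sit.

The compounds shown leave open whether ethyl, benzyl or a plain hydrogen on this nitrogen would give a number that can be read. They also leave open how isopropyl would behave with the (5-(tert-butyl)-1,2-oxazol-3-yl)amino group of compound 1 on the carbonyl carbon.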